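Swapping the oxetane for isobutyl on the sulfonyl

The source may report more compounds than this note shows. Statements on the series, on what has been measured and on what is new or still open speak of the compounds shown alone.

Measured compounds:
compound 1, `CCN(CC)S(=O)(=O)c1ccc(S(=O)(=O)N2CCC[C@@H](C(=O)N[C@H]3CC[C@H](OC)CC3)C2)cc1`, 1350 nM
compound 2, `O=C([C@@H]1CCCN(S(=O)(=O)c2ccc(S(=O)(=O)C3COC3)cc2)C1)N1CCC(F)(F)CC1`, 110 nM
compound 3, `CCN(CC)S(=O)(=O)c1ccc(S(=O)(=O)N2CCC[C@@H](C(=O)N3CCOCC3)C2)cc1`, 350 nM

The numbers come from a functional assay on MIA PaCa-2 cells (Homo sapiens) for inhibition, read by MTT assay, with a stated time of 7 days; on this read-out higher numbers stand for weaker inhibition and lower numbers for stronger inhibition. Compound 2 stands lowest of the three, and its gaps to both others are beyond the scatter: compound 3 gives 350 nM and compound 1 gives 1350 nM. Among the compounds with values here, the one measured step, a 3.9-fold lower number from compound 1 to compound 3 (0.59 log units; beyond the scatter), concerns the amide end of the shared core and tells nothing about the sulfonyl end.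

Compound 4, `CC(C)CS(=O)(=O)c1ccc(S(=O)(=O)N2CCC[C@@H](C(=O)N3CCC(F)(F)CC3)C2)cc1`, differs from compound 2 only at that sulfonyl end: isobutyl in place of oxetan-3-yl on a sulfonyl sulfur. Within the data shown here, no measured pair in this set changes the group on the sulfonyl sulfur, so there is no step that bears on this change, and no direction can be read from the data. The amide portion of compound 4 is the same as in compound 2, whose value 110 nM is therefore the natural anchor. A step of no size beyond the scatter is expected in this assay, in either direction.

Compound 4 is accordingly estimated at 160 nM, with a range from 50 nM to 500 nM, meaning an expected step of a 1.5-fold higher number from compound 2 to compound 4 (0.16 log units; within the scatter).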

Compound 4, half-maximal inhibitory concentration: 80 nM
The estimate for compound 4 lay 2.0-fold (0.30 log units) above the measured number; the range from low to high includes it.
By their numbers in this assay, from the lowest: compounds 4 and 2 (each within the scatter of the next); then compound 3; then compound 1.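

In this assay, within the data shown here, the change to isobutyl on the sulfonyl sulfur gives a 1.4-fold lower number from compound 2 to compound 4 (0.14 log units; within the scatter), the only measured step at this position, so a four-membered ring with one hetero atom and one hydrogen-bond acceptor gives way to an open group of the same heavy-atom count with no hydrogen-bond acceptor, and the read-out stays within the scatter. For this pair, with its shared amide end, neither the ring nor its oxygen is therefore required for a number of this size, although a single pair cannot show whether the same holds with a different amide end. Nothing available here accounts for the two groups reading alike.

The compounds shown leave open whether a group on the sulfonyl sulfur that carries an amine or a carboxylic acid, or a chain longer than isobutyl, would also stay within the scatter of these two. They also leave open how the diethylamino group on the sulfonyl of compound 1 and compound 3 compares with isobutyl or oxetan-3-yl with the amide end held the same.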